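The source may report more compounds than this note shows. Statements on the series, on what has been measured and on what is new or still open speak of the compounds shown alone.

Three compounds with a shared core have been measured in a functional assay on HT-29 cells (Homo sapiens) for inhibition, read by sulforhodamine B assay, with a stated time of 48 h; a lower number here means a stronger inhibitor of growth, a higher number a weaker inhibitor of growth:

Compound 1 `CC1=CC[C@H](C(C)(C)NC(=S)N/N=C/c2ccccc2)CC1` gives 8800 nM.
Compound 2 `CC1=CC[C@H](C(C)(C)NC(=S)N/N=C/c2ccccc2Cl)CC1` gives 71300 nM.
Compound 3 `CC1=CC[C@H](C(C)(C)NC(=S)N/N=C/c2ccc(Cl)cc2)CC1` gives 13600 nM.

Among the three numbers, compound 3 holds the second highest: its gap to compound 1, a 1.5-fold higher number from compound 1 to compound 3 (0.19 log units; within the scatter), is within the scatter, whereas its gap to compound 2, a 5.2-fold lower number from compound 2 to compound 3 (0.72 log units; beyond the scatter), is beyond it. The measured steps of an 8.1-fold higher number from compound 1 to compound 2 (0.91 log units; beyond the scatter) and a 1.5-fold higher number from compound 1 to compound 3 (0.19 log units; within the scatter) each add a chloro on an aromatic carbon of the phenyl, and a 5.2-fold lower number from compound 2 to compound 3 (0.72 log units; beyond the scatter) exchanges 2-chlorophenyl for 4-chlorophenyl.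

Compound 4 `CC1=CC[C@H](C(C)(C)NC(=S)N/N=C/c2ccco2)CC1` differs from compound 3 by furan-2-yl in place of 4-chlorophenyl on a carbon with a double bond to nitrogen. Among the compounds with values here, no measured step exchanges the whole ring; all three only add or relocate a chloro, so they bear on this change only loosely. On that basis the account expects for compound 4 a step of a 1.1-fold higher number from compound 3 to compound 4 (0.04 log units; within the scatter) that stays within the scatter. Compound 4 is accordingly estimated at 15000 nM in this assay, within a range from 5000 nM to 50000 nM.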

Compound 4, concentration for 50% growth inhibition: 7200 nM
For compound 4 the middle estimate is 2.1-fold (0.32 log units) above the measured one, within the range that was stated.
By their numbers in this assay, from the lowest: compounds 4, 1 and 3 (each within the scatter of the next); then compound 2.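

In this assay, within the data shown here, the first exchange of the whole ring on the carbon with a double bond to nitrogen leaves the number within the scatter, whether furan-2-yl replaces 4-chlorophenyl (a 1.9-fold lower number from compound 3 to compound 4 (0.28 log units; within the scatter)) or phenyl (a 1.2-fold lower number from compound 1 to compound 4 (0.09 log units; within the scatter)). Only against 2-chlorophenyl does the same exchange go beyond the scatter (a 9.9-fold lower number from compound 2 to compound 4 (1.00 log units; beyond the scatter)), so among these four compounds a five-membered aromatic ring with one hetero atom serves here as well as phenyl, and compound 2 alone stands apart. No evidence on the cause of these differences is at hand.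

The compounds shown leave open whether a thiophene ring at this place would match furan-2-yl. They also leave open whether a phenyl carrying an amine or a carboxylic acid would stay with compounds 1, 3 and 4 or move towards compound 2.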